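Chloro for fluoro on the aryl of compound 1

A few compounds are considered here, and "the series" means these few. Any claim that something is new, unique, unknown or untested is made for them only; others in the source may bear on it.

Measured so far:
compound 1, `O=C1CC(c2nc(-c3ccc(F)cc3)no2)CN1c1ccc(Cl)c(Cl)c1`: 2300 nM
compound 2, `O=c1oc2ccccc2n1Cc1nc(-c2cccc(Cl)c2)no1`: > 10000 nM
compound 3, `Cc1ccc(N2CC(c3nc(-c4cccc(C)c4)no3)CC2=O)cc1`: 1300 nM

In an in vitro functional assay on HEK293-A cells for positive allosteric modulation of metabotropic glutamate receptor 5 (Homo sapiens), read by FLIPR and calcium flux (a higher number here means that more compound is needed for the effect, a lower number that less compound is needed), compound 1 gives 2300 nM, the higher of the two numbers at hand. Compound 3 gives 1300 nM in this assay, and the gap to compound 1 lies within the scatter, so no order between the two can be read. Compound 2 reaches only a limit in this assay, > 10000 nM; this is the limit of > 10000 nM in this assay, at which 1 of the 3 values shown sits.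

Compound 4, `O=C1CC(c2nc(-c3ccc(Cl)cc3)no2)CN1c1ccc(Cl)c(Cl)c1`, is not yet measured. It differs from compound 1 in one place: chloro in place of fluoro on an aromatic carbon. Among the measured compounds shown here, no pair of measured compounds shares this change, so its size cannot be taken from the numbers at hand. The expected step of a 1.3-fold lower number from compound 1 to compound 4 (0.11 log units; within the scatter) is small, if anything toward a lower number, and not clearly beyond the scatter. Compound 4 is therefore estimated at 1800 nM in this assay, with a range from 700 nM to 5000 nM.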

Compound 4, half-maximal effective concentration: 1100 nM
Beside the measured number, compound 4's estimate is 1.6-fold (0.21 log units) above it; the measured number falls inside the stated range.
By their numbers in this assay, from the lowest: compounds 4, 3 and 1 (each within the scatter of the next, the first and the last beyond it). At a limit, above all of these: compound 2.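

Among the compounds shown here, the exchange of 4-fluorophenyl for 4-chlorophenyl provides the only single-place step so far, read in this assay: a 2.1-fold lower number from compound 1 to compound 4 (0.32 log units; beyond the scatter). The substituent on this aromatic carbon, para to a large group, therefore affects the read-out, although the step is modest and rests on a single pair. Nothing at hand bears on why chloro and fluoro differ here.

This one pair leaves open whether the same exchange would give a similar step with other groups on the far side of the shared core, such as those of compound 3. It also leaves open how a nitrile, a methoxy group or an amine on this carbon would compare with chloro and fluoro.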